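The source may report more compounds than this note shows. Statements on the series, on what has been measured and on what is new or still open speak of the compounds shown alone.

Measured compounds:
compound 1 `NS(=O)(=O)c1cc(-c2nnc(CN3CCN(Cc4ccccc4)CC3)o2)c(Cl)cc1SCc1ccccc1`, 125000 nM
compound 2 `NC(=O)c1cn(Cc2nnc(-c3cc(S(N)(=O)=O)c(SCc4ccccc4)cc3Cl)o2)nn1`, 78000 nM
compound 3 `COc1ccc(-c2cn(Cc3nnc(-c4cc(S(N)(=O)=O)c(SCc5ccccc5)cc4Cl)o3)nn2)cc1`, 1500000 nM

In a functional assay on MCF7 cells (Homo sapiens) for cytotoxicity, read by MTT assay, with a stated time of 72 h (on this read-out higher numbers stand for weaker inhibition and lower numbers for stronger inhibition), compound 2 gives 78000 nM, the lowest of the three numbers. Compound 1 lies nearest to it, and the two values sit within the scatter of each other, so no order between them can be claimed. Compound 3 lies furthest away: a 19-fold higher number from compound 2 to compound 3 (1.28 log units; beyond the scatter), a large loss.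

Compound 4 `NS(=O)(=O)c1cc(-c2nnc(CNC(=O)c3ccccc3)o2)c(Cl)cc1SCc1ccccc1` is the unmeasured partner of compound 2. The change is benzamido in place of 4-carbamoyl-1H-1,2,3-triazol-1-yl on a saturated chain carbon bound to an aromatic carbon. Among the measured compounds shown here, no measured step covers this exact exchange. For the measured compounds named here, the one step that bears on it at all, from compound 2 to compound 3, shows that enlarging the substituent on the carbamoyl-bearing ring of compound 2 with an additional aromatic ring cost a great deal in this assay. Compound 4 also gains an aromatic ring, but it gives up the triazole ring at the same time, so that step is only a loose guide, and compound 1 shows that a different group on the same chain carbon leaves the number close to that of compound 2.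

Compound 4 is therefore expected to remain near compound 2, with a small step, if any, toward a higher number: a 1.5-fold higher number from compound 2 to compound 4 (0.19 log units; within the scatter). The estimate for compound 4 in this assay is 120000 nM, with a range from 40000 nM to 400000 nM.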

Compound 4, half-maximal inhibitory concentration: 66000 nM
The estimate for compound 4 lay 1.8-fold (0.26 log units) above the measured number; measured number inside the range.
By their numbers in this assay, from the lowest: compounds 4, 2 and 1 (each within the scatter of the next); then compound 3.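

In this assay, benzamido in place of 4-carbamoyl-1H-1,2,3-triazol-1-yl on the chain carbon gives a 1.2-fold lower number from compound 2 to compound 4 (0.07 log units; within the scatter) and so shows no readable change, which means that among these compounds the triazole ring is not required to hold the number at this level. The large step seen earlier is a 19-fold higher number from compound 2 to compound 3 (1.28 log units; beyond the scatter). Compound 4 also carries an added aromatic ring, and it stays within the scatter of compound 2. No measurement available here accounts for why these two groups read alike.

Going by these compounds, whether the amide hydrogen of benzamido matters remains open, as does whether acetamido or a carboxylic acid on the same chain carbon would read the same. On these data alone, it is also open whether a 4-methoxybenzamido group would repeat the loss seen with the 4-methoxyphenyl group of compound 3.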